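A few compounds are considered here, and "the series" means these few. Any claim that something is new, unique, unknown or untested is made for them only; others in the source may bear on it.

Measured so far in a physicochemical assay for solubility, read by HPLC; a higher number here means a more soluble compound, a lower number a less soluble compound:
- Compound 1 `O=C(c1ccccc1F)N1CCN(c2nc(=O)c3cc(C(F)(F)F)cc([N+](=O)[O-])c3s2)CC1`: 3.1 ug/mL
- Compound 2 `O=C(c1ccc(Cl)cc1)N1CCN(c2nc(=O)c3cc(C(F)(F)F)cc([N+](=O)[O-])c3s2)CC1`: 5.19 ug/mL
- Compound 3 `O=c1nc(N2CCN(CC3CCCCC3)CC2)sc2c([N+](=O)[O-])cc(C(F)(F)F)cc12`: 9.07 ug/mL

Compound 3, at 9.07 ug/mL, stands clear of compound 1 but within the scatter of compound 2. Compound 4 `O=C(C1CC1)N1CCN(c2nc(=O)c3cc(C(F)(F)F)cc([N+](=O)[O-])c3s2)CC1`, not yet measured, has cyclopropylcarbonyl in place of cyclohexylmethyl on an amine nitrogen in a ring. Within the data shown here, two measured steps bear on this, both running the opposite way, from a group joined through a carbonyl to cyclohexylmethyl: a 2.9-fold higher number from compound 1 to compound 3 (0.47 log units; beyond the scatter), and a 1.7-fold higher number from compound 2 to compound 3 (0.24 log units; within the scatter). Neither involves cyclopropylcarbonyl, so they are only a rough guide. The step expected in this assay is a 1.5-fold lower number from compound 3 to compound 4 (0.18 log units; within the scatter), toward a lower number but not beyond the scatter. For compound 4 the estimate is 6 ug/mL, with an expected range of 2.5 ug/mL to 15 ug/mL.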

Compound 4, solubility: 52.9 ug/mL
Estimate against measurement, compound 4: 8.8-fold (0.95 log units) below; measured number outside the range, above it.
By their numbers in this assay, from the lowest: compounds 1, 2 and 3 (each within the scatter of the next, the first and the last beyond it); then compound 4.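

Compound 1, compound 2 and compound 3 gave little hint of how far this position can move the number in this assay: cyclopropyl on the carbonyl carbon gives a 10-fold higher number from compound 2 to compound 4 (1.01 log units; beyond the scatter) and a 17-fold higher number from compound 1 to compound 4 (1.23 log units; beyond the scatter). A carbonyl on this amine nitrogen does not by itself hold the number down, as cyclopropylcarbonyl also outdoes cyclohexylmethyl, with a 5.8-fold higher number from compound 3 to compound 4 (0.77 log units; beyond the scatter). No measurement here gives a reason for these steps.

As far as these compounds go, whether the step belongs to the cyclopropyl ring itself or simply to losing the aromatic ring remains open. An acetyl or cyclohexylcarbonyl group on this nitrogen would help separate the two.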